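Methyl on the anilide ring against a tolerated-concentration limit

The source may hold more compounds than are shown below. What is called first, only, known or untested is meant among the compounds shown, and "the series" means these compounds.

Two cores are present. Compound 2 `O=C(CSc1nccn1-c1cccc2ccccc12)Nc1ccccc1Br` and compound 1 `Cc1ccc(NC(=O)CSc2nccn2-c2cccc3ccccc23)c(Br)c1` share one of them; compound 3 `O=C(CSc1nccn1-c1ccc(Cl)cc1)Nc1ccccc1Br` and the yet unmeasured compound 4 `Cc1ccc(NC(=O)CSc2nccn2-c2ccc(Cl)cc2)c(Br)c1` share the other. The difference between the two cores is not broken down here.

In an ADME assay on MT4 cells (Homo sapiens) for cytotoxicity, read by MTT assay (a lower number here means that less compound is tolerated, a higher number that more compound is tolerated), compound 2 gives 30500 nM. In this assay compound 1 gives 29400 nM. The change from compound 2 to compound 1 is methyl in place of hydrogen on an aromatic carbon, and it made a 1.0-fold lower number from compound 2 to compound 1 (0.02 log units; within the scatter).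

For compound 3 this assay reports only a limit, > 300000 nM. Among the three values recorded, compound 3 alone accounts for (the limit of > 300000 nM in this assay, at which 1 of the 3 values shown sits).

The change from compound 3 to compound 4 is methyl in place of hydrogen on an aromatic carbon. Its place reads word for word as that of the change from compound 2 to compound 1, so it is the same change, here applied on the second core. In the measured pair this change left the tolerated concentration essentially unmoved, as a 1.0-fold lower number from compound 2 to compound 1 (0.02 log units; within the scatter) shows. The starting point on the second core, compound 3, is itself a limit rather than a number, so the same change is expected to leave compound 4 at that limit as well. Compound 4 is therefore expected to give 300000 nM, with a range from 120000 nM to 300000 nM, most likely again reported only as a limit. The expected result means a number no higher from compound 3 to compound 4 (the limit leaves the size open).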

Compound 4, half-maximal cytotoxic concentration: 221000 nM
The estimate for compound 4 lay 1.4-fold (0.13 log units) above the measured number, within the range that was stated.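

In this assay, the change from 2-bromophenyl to 2-bromo-4-methylphenyl on the second core gives an at least 1.3-fold lower number from compound 3 to compound 4 (0.13 log units; that floor lies within the scatter). Compound 3 stands at > 300000 nM, which is a limit of the assay and not a number, so only a floor can be read for this step: the limit of > 300000 nM in this assay, at which 1 of the 4 values shown sits. Carried from one core to the other, the methyl change gives no readable step beyond the scatter on either core, but the true size of the step on the second core stays unknown, so the data neither confirm that the change carries over unaltered nor show that it behaves differently: the same change on two cores in this assay, a 1.0-fold lower number (0.02 log units; within the scatter) from compound 2 to compound 1 and an at least 1.3-fold lower number (0.13 log units; that floor lies within the scatter) from compound 3 to compound 4; the limit leaves it open whether they differ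

The compounds shown hold only hydrogen or methyl at this place on the anilide ring, so it remains open whether an ethyl group, a methoxy group, an amine or a carboxylic acid there would shift the tolerated concentration on either core. As far as these compounds go, it also remains open how the methyl change would read on the second core from a starting compound with a measured number rather than a limit, for instance one carrying a methoxy group in place of the chloro group.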